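The source may hold more compounds than are shown below. What is called first, only, known or untested is meant among the compounds shown, and "the series" means these compounds.

Series notes. Among the compounds with values here, the read-out throughout is an ADME assay on TERT-RPE1 cells (Homo sapiens) for cytotoxicity, read by MTT assay, with a stated time of 72 h (a lower number here means a stronger inhibitor, a higher number a weaker inhibitor), and only one compound gives a number in it. Within the data shown here, compound 1 `COc1ccc(/C=C2/CN(C)/C(=N/c3ccc(C)cc3)S2)cc1` gives 65700 nM in this assay, the single measured value in the set and thus the only reference point for the shared core. Compound 2 `C=C1CN(C)/C(=N/c2ccccc2)S1` gives > 100000 nM in this assay, which is a limit of the assay rather than a number. Among the measured compounds shown here, that the limit of > 100000 nM in this assay, at which 1 of the 2 values shown sits, is the only other entry, so no step between measured compounds can be drawn, and nothing about the size of any change on the core is known from data.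

Compound 3 `COc1ccc(/C=C2/CN(C)/C(=N/c3ccc(C(F)(F)F)cc3)S2)cc1` is the next member to be run in this assay. It differs from compound 1 by trifluoromethyl in place of methyl on an aromatic carbon. For the measured compounds named here, with no measured step to lean on, the expectation is that the change from compound 1 to compound 3 moves the value little, with a step of a 1.3-fold lower number from compound 1 to compound 3 (0.12 log units; within the scatter) expected to lie within the usual scatter. Compound 3 is therefore estimated at 50000 nM in this assay, with a range from 20000 nM to 110000 nM.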

Compound 3, half-maximal inhibitory concentration: 72000 nM
Beside the measured number, compound 3's estimate is 1.4-fold (0.16 log units) below it; the range from low to high includes it.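

Trifluoromethyl in place of methyl, on an aromatic carbon para to a large group, gives a 1.1-fold higher number from compound 1 to compound 3 (0.04 log units; within the scatter) in this assay, and this is the first step measured on the shared core. At this position, a group of 4 heavy atoms in place of one of 1 heavy atom therefore leaves the read-out within the scatter, so the change of size and atom type made here cannot be told from repeat measurement. No measured property in these data bears on this step.

Compound 2 is a limit of the assay and not a number, and steps to it cannot be read: the limit of > 100000 nM in this assay, at which 1 of the 3 values shown sits. Going by these compounds, whether a group of a different kind at this position, such as an amine, a carboxylic acid or a longer chain, would give a step beyond the scatter stays open, and so does the effect of any change elsewhere on the shared core, since this single step speaks for one position and one replacement only.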